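The source may report more compounds than this note shows. Statements on the series, on what has been measured and on what is new or still open speak of the compounds shown alone.

Values measured so far in a functional assay on K562 cells (Homo sapiens) for antiproliferative activity, read by CCK-8 assay, with a stated time of 48 h; a higher number here means a weaker inhibitor, a lower number a stronger inhibitor:

- compound 1 `O=C(CCCCCCOc1ccc(-c2nnc(-c3ccccc3)s2)cc1)NO`: 16000 nM
- compound 2 `O=C(CCCCOc1cccc(-c2nnc(-c3ccccc3)s2)c1)NO`: 2100 nM
- compound 3 `O=C(CCCCCOc1cccc(-c2nnc(-c3ccccc3)s2)c1)NO`: 910 nM

Compound 3 has the lowest number of the three, at 910 nM, which places it below both compound 2 and compound 1. The next analogue, compound 4 `O=C(CCCCCCOc1cccc(-c2nnc(-c3ccccc3)s2)c1)NO`, has not yet been measured. It differs from compound 3 by a single change: (hydroxycarbamoyl)methyl in place of hydroxycarbamoyl on a saturated chain carbon, five bonds along the chain from an oxygen on an aromatic ring. In words, (hydroxycarbamoyl)methyl stands in place of hydroxycarbamoyl on a saturated chain carbon, five bonds along the chain from an oxygen on an aromatic ring.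

Going by the values given here, the one measured step that bears on this is the same change made four bonds along the chain: a 2.3-fold lower number from compound 2 to compound 3 (0.36 log units; beyond the scatter). That step was modest. Among the compounds with values here, compound 1 has no measured step to the others, so it gives no size for this change. A single step is a thin guide, but another modest fall in the number is expected in this assay. Compound 4 is estimated at 550 nM, with an expected range of 200 nM to 1600 nM. The expected step is a 1.7-fold lower number from compound 3 to compound 4 (0.22 log units; within the scatter).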

Compound 4, half-maximal inhibitory concentration: 3200 nM
Estimate against measurement, compound 4: 5.8-fold (0.76 log units) below; the whole stated range lies below it.
By their numbers in this assay, from the lowest: compound 3; then compounds 2 and 4 (each within the scatter of the next); then compound 1.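

In this assay, the change that lowered the number one bond earlier does not do so again: (hydroxycarbamoyl)methyl in place of hydroxycarbamoyl, five bonds along the chain from an oxygen on an aromatic ring, gives a 3.5-fold higher number from compound 3 to compound 4 (0.55 log units; beyond the scatter), so the direction of this change depends on where along the chain it is made. Measured from the shorter chain, 2-(hydroxycarbamoyl)ethyl in place of hydroxycarbamoyl gives a 1.5-fold higher number from compound 2 to compound 4 (0.18 log units; within the scatter), which leaves compound 2 and compound 4 level and compound 3 alone as the low point of these three chains. Nothing available explains this reversal.

The compounds shown leave open whether a longer chain, such as 4-(hydroxycarbamoyl)butyl in place of hydroxycarbamoyl, would continue the trend seen at compound 4. They also leave open what a carboxylic acid in place of the hydroxycarbamoyl end of compound 3 would do to its number.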